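Chain extension at the aryl ether of compound 3

The compounds below may be only part of what the source reports. "The series", "measured", "known", "first", "only" and "open" are said of these compounds alone.

Measured in an assay on HEK293 cells for displacement of a labelled ligand from Neuronal acetylcholine receptor; alpha3/beta4 (Homo sapiens), read by scintillation counting, with a stated time of 120 min; on this read-out higher numbers stand for weaker inhibition and lower numbers for stronger inhibition:
- compound 1 `Fc1cccc(-c2cn(C3CN4CCC3CC4)nn2)c1`: 5.24 nM
- compound 2 `c1ccc(COc2cccc(-c3cn(C4CN5CCC4CC5)nn3)c2)cc1`: 7.57 nM
- compound 3 `FCCOc1cccc(-c2cn(C3CN4CCC3CC4)nn2)c1`: 20.9 nM
- compound 4 `FCCCOc1cccc(-c2cn(C3CN4CCC3CC4)nn2)c1`: not yet measured

Compound 3 holds the highest number of the three. The nearest is compound 2, by a 2.8-fold higher number from compound 2 to compound 3 (0.44 log units; beyond the scatter); the furthest is compound 1, by a 4.0-fold higher number from compound 1 to compound 3 (0.60 log units; beyond the scatter). Compound 1 and compound 2 differ only by a 1.4-fold higher number from compound 1 to compound 2 (0.16 log units; within the scatter).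

The step to compound 4 is fluoromethyl in place of fluoro on a saturated chain carbon, two bonds along the chain from an oxygen on an aromatic ring. For the measured compounds named here, two measured steps touch this region: the introduction of the whole 2-fluoroethoxy group, a 4.0-fold higher number from compound 1 to compound 3 (0.60 log units; beyond the scatter), and the exchange on the chain carbon, a 2.8-fold higher number from compound 2 to compound 3 (0.44 log units; beyond the scatter). Going by the values given here, neither is a one-carbon lengthening of the chain itself, so no step bears on it directly. Both nearby changes moved the number by modest amounts, and a single added carbon is a smaller alteration than either. The expectation for this assay is therefore a step of a 1.2-fold lower number from compound 3 to compound 4 (0.06 log units; within the scatter), with no clear direction beyond the scatter. Compound 4 is estimated at 18 nM, with a range of 7 nM to 45 nM.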

Compound 4, inhibition constant: 44.4 nM
For compound 4 the middle estimate is 2.5-fold (0.39 log units) below the measured one; the measured number falls inside the stated range.
By their numbers in this assay, from the lowest: compounds 1 and 2 (each within the scatter of the next); then compound 3; then compound 4.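

In this assay a single added carbon on the ether chain is not neutral: the step from 2-fluoroethoxy to 3-fluoropropoxy lies beyond the scatter (a 2.1-fold higher number from compound 3 to compound 4 (0.33 log units; beyond the scatter)). Among the fluorinated ethers and the fluoro parent the number rises with each lengthening, and the full change from fluoro to 3-fluoropropoxy is the widest seen here (an 8.5-fold higher number from compound 1 to compound 4 (0.93 log units; beyond the scatter)). Compound 2 goes against a simple reading by chain size, since its benzyloxy group stands well apart from 3-fluoropropoxy (a 5.9-fold higher number from compound 2 to compound 4 (0.77 log units; beyond the scatter)), so a larger group on the oxygen does not by itself give a higher number.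

As far as these compounds go, whether the rise continues with a 4-fluorobutoxy chain, and whether a plain propoxy group without fluorine behaves the same, stays open. Nothing available explains these steps.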